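The source may hold more compounds than are shown below. What is called first, only, known or untested is meant among the compounds shown, and "the series" means these compounds.

Measured compounds:
- compound 1 `CNC(=O)c1cccc(-c2cnc(Nc3ccc(F)cc3)o2)c1` gives 0.025 h in an ADME assay on microsomes from liver (Mus musculus) for metabolic stability, read by LC-MS, using NADPH; on this read-out lower numbers stand for a shorter-lived compound and higher numbers for a longer-lived compound
- compound 2 `Cc1noc(-c2cccc(-c3cnc(Nc4ccc(F)cc4)o3)c2)n1` gives 0.383 h in this assay

Compound 2 stands highest of the two numbers in this assay; the nearest, compound 1, sits a large gap lower. Compound 3 `CC(=O)Nc1cccc(-c2cnc(Nc3ccc(F)cc3)o2)c1` differs from compound 2 by acetamido in place of 3-methyl-1,2,4-oxadiazol-5-yl on an aromatic carbon. Going by the values given here, the only step bearing on it is a 15-fold higher number from compound 1 to compound 2 (1.19 log units; beyond the scatter), which swapped an amide-bearing group for the same oxadiazole at this position. Going back to an amide-bearing group, a fall of comparable size is therefore expected, though not necessarily the full way. For compound 3 the estimate is 0.06 h (range 0.02 h to 0.2 h), an expected step of a 6.4-fold lower number from compound 2 to compound 3 (0.81 log units; beyond the scatter).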

Compound 3, half-life: 0.173 h
For compound 3 the middle estimate is 2.9-fold (0.46 log units) below the measured one, and the stated range covers the measured number.
By their numbers in this assay, from the lowest: compound 1; then compound 3; then compound 2.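

In this assay, acetamido in place of methylcarbamoyl on an aromatic carbon gives a 6.9-fold higher number from compound 1 to compound 3 (0.84 log units; beyond the scatter), so among the compounds shown, a short half-life does not follow from carrying an amide-bearing group at this position. The 3-methyl-1,2,4-oxadiazol-5-yl group still holds the highest number, with a 2.2-fold lower number from compound 2 to compound 3 (0.35 log units; beyond the scatter) on changing to acetamido, so much of its gain over methylcarbamoyl is reached without a ring. No measurement here accounts for the difference between the two amide-bearing groups.

On these data alone, whether an amine, a carboxylic acid or a propionamido group at this position would fall nearer compound 1 or compound 2 remains open. Also open, as far as these compounds go, is whether the order of these three groups would hold on a different core.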